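From trifluoromethyl to chloro on a shared core

A few compounds are considered here, and "the series" means these few. Any claim that something is new, unique, unknown or untested is made for them only; others in the source may bear on it.

Measured in a functional assay on SSMC-7721 cells (Homo sapiens) for inhibition, read by MTT assay, with a stated time of 72 h; on this read-out higher numbers stand for weaker inhibition and lower numbers for stronger inhibition:
Compound 1 `COc1cc(O)c(CC=C(C)C)c(O)c1C(=O)/C=C/c1ccc(C(F)(F)F)cc1` gives 10700 nM
Compound 2 `COc1cc(O)cc(O)c1C(=O)/C=C/c1cccc([N+](=O)[O-])c1` gives 20100 nM
Compound 3 `COc1cc(OC)c(C(=O)/C=C/c2ccc(C(F)(F)F)cc2)c(OC)c1` gives 15700 nM

Compound 3 stands among these three numbers, within the scatter of both compound 1 and compound 2. Compound 4 `COc1cc(OC)c(C(=O)/C=C/c2ccc(Cl)cc2)c(OC)c1` follows from compound 3 through one exchange, chloro in place of trifluoromethyl on an aromatic carbon. For the measured compounds named here, no measured pair isolates a single change, so the data do not size this exchange directly. The expectation rests on compound 3 at 15700 nM and on the narrow spread of the other two values. The expected result in this assay is a 1.0-fold lower number from compound 3 to compound 4 (0.02 log units; within the scatter), a step none beyond the scatter. For compound 4 the estimated value is 15000 nM, with an expected range from 7000 nM to 32000 nM.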

Compound 4, half-maximal inhibitory concentration: 11700 nM
Compound 4: middle estimate off by 1.3-fold (0.11 log units), on the high side; measured number inside the range.
By their numbers in this assay, from the lowest: compounds 1, 4, 3 and 2 (each within the scatter of the next).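

For the compounds shown here, compound 3 and compound 4 form the first pair here that isolates a single exchange. In this assay, chloro in place of trifluoromethyl on an aromatic carbon, para to a large group, gives a 1.3-fold lower number from compound 3 to compound 4 (0.13 log units; within the scatter), so at this position the two groups cannot be told apart on this read-out. Nothing available bears on why this step is so small.

From the compounds shown here alone, it remains open whether an amine or a carboxylic acid at this position would also stay within the scatter. Going by these compounds, whether the same exchange would read alike on the core of compound 1 is also open.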